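Moving the Fluorine on the Cyanophenyl Arm

This account rests on a few compounds, and the source may have more. Where it says the series, first, only, none or still open, it means among the compounds named here.

Compound 1 `Cc1cc(-c2ccc(C#N)c(F)c2)ccc1Oc1ccnc(Nc2ccc(C#N)cc2)n1` — > 296000 nM
Compound 2 `N#Cc1ccc(Nc2nccc(Oc3ccc(-c4ccc(C#N)c(F)c4)cc3F)n2)cc1` — > 294000 nM

Compound 1 was tested in a functional assay on MT4 cells (Homo sapiens) for cytotoxicity, read by MTT assay, with a stated time of 5 days; a higher number here means that more compound is tolerated, a lower number that less compound is tolerated. In this assay compound 1 gives > 296000 nM, and that value is a limit of the assay, not a number. Compound 2 differs from compound 1 by fluoro in place of methyl on an aromatic carbon; in this assay compound 2 gives > 294000 nM, which is likewise a limit. Among the compounds with values here, the only measured step, a step that the two limits leave unreadable from compound 1 to compound 2, therefore cannot be sized, because the limit of > 294000 nM in this assay, at which 1 of the 2 values shown sits, and the limit of > 296000 nM in this assay, at which 1 of the 2 values shown sits, hold both values at the edge of what the assay reports. Compound 1 thus stands at a limit, and the one neighbour shown stands at a limit too.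

Compound 3 `Cc1cc(-c2ccc(C#N)cc2F)ccc1Oc1ccnc(Nc2ccc(C#N)cc2)n1` has not yet been measured in this assay. It differs from compound 1 by 4-cyano-2-fluorophenyl in place of 4-cyano-3-fluorophenyl on an aromatic carbon. Within the data shown here, no measured step follows this change, and the one step on record is unreadable. The step from compound 1 to compound 3 is expected to be a step that the limit leaves unreadable from compound 1 to compound 3, that is, none beyond the scatter. Compound 3 is therefore estimated at 300000 nM in this assay, within 150000 nM to 600000 nM, most likely reported once more as a limit.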

Compound 3, half-maximal cytotoxic concentration: > 296000 nM
Compound 3 gave a limit, no number; the forecaster's own chance of this, stated with the estimate: 85%; the middle value does not contradict the limit.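

Compound 1 and compound 3 both give a limit and not a number, so no step between them can be read, because both values sit at the edge of what is reported: the limit of > 296000 nM in this assay, at which 2 of the 3 values shown sit.

The compounds shown leave open whether 4-cyano-2-fluorophenyl in place of 4-cyano-3-fluorophenyl shifts the half-maximal cytotoxic concentration at all in this assay.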